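Phenyl ether variation on the shared core: acetoxy analogue

This account rests on a few compounds, and the source may have more. Where it says the series, first, only, none or still open, it means among the compounds named here.

Measured so far:
Compound 1, `COc1cccc(OC)c1OCCNC[C@H]1Oc2ccccc2O[C@@H]1c1ccc(O)cc1`: in a functional assay for antagonist activity at Adrenergic receptor alpha-1 (Rattus norvegicus) (a higher number here means weaker binding, a lower number tighter binding), compound 1 gives 14.5 nM.
Compound 2, `COc1ccc([C@H]2Oc3ccccc3O[C@@H]2CNCCOc2c(OC)cccc2OC)cc1`: in this assay compound 2 gives 2.14 nM.

For the measured compounds named here, compound 2 holds the lowest of the two numbers; its nearest neighbour is compound 1, and the single measured step, a 6.8-fold lower number from compound 1 to compound 2 (0.83 log units; beyond the scatter), lies beyond the scatter and is of modest size. Going by the values given here, that step is the only comparison in hand at the oxygen on the aromatic ring.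

Compound 3, `COc1cccc(OC)c1OCCNC[C@H]1Oc2ccccc2O[C@@H]1c1ccc(OC(C)=O)cc1`, differs from compound 2 by acetyl in place of methyl on an oxygen on an aromatic ring. Among the compounds with values here, no measured pair swaps methyl for acetyl, so the step from compound 2 to compound 3 has no direct precedent. The step of a 6.8-fold lower number from compound 1 to compound 2 (0.83 log units; beyond the scatter) shows only that a substituent on this oxygen is accepted in this assay; whether a larger acetyl is accepted as well as methyl is not settled by any measured compound. Compound 3 is therefore expected to stay close to compound 2, with the step of a 2.1-fold higher number from compound 2 to compound 3 (0.32 log units; beyond the scatter) anticipated to fall within or just beyond the scatter, leaning toward a higher number. Compound 3 is estimated at 4.5 nM, expected between 1.5 nM and 14 nM.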

Compound 3, dissociation constant: 7.59 nM
Estimate against measurement, compound 3: 1.7-fold (0.23 log units) below, within the range that was stated.
By their numbers in this assay, from the lowest: compound 2; then compounds 3 and 1 (each within the scatter of the next).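

At the oxygen on the aromatic ring, this assay now separates two substituents: the change from methoxy to acetoxy gives a 3.5-fold higher number from compound 2 to compound 3 (0.55 log units; beyond the scatter) and so does not preserve the low number seen with methyl. Acetyl in place of hydrogen gives a 1.9-fold lower number from compound 1 to compound 3 (0.28 log units; within the scatter) and leaves compound 3 unresolved from compound 1, so the shift seen in a 6.8-fold lower number from compound 1 to compound 2 (0.83 log units; beyond the scatter) does not extend to every substituent on this oxygen, and among the three groups shown only methyl stands apart from the others. No measured information accounts for the gap between methyl and acetyl at this position.

The compounds shown leave open whether the low number belongs to methyl alone or extends to an ethyl group or a longer alkyl chain on the same oxygen. They also leave open how a carbamate or a benzoyl group on this oxygen would compare with acetyl, and therefore whether the carbonyl, which enters with the acetyl, or the larger count of heavy atoms goes with the higher number.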